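Notes on a ring-nitrogen swap in an amide series

The compounds below may be only part of what the source reports. "The series", "measured", "known", "first", "only" and "open" are said of these compounds alone.

Three members of the series have been run in a toxicity assay on HepG2 cells (Homo sapiens) for inhibition, read by CellTiter-Glo, with a stated time of 48 h; a higher number here means a weaker inhibitor, a lower number a stronger inhibitor. Compound 1 `CCOc1ccc2nc(C)cc(OCC(=O)Nc3cc(C)cc(C)c3)c2c1` returns only a limit of the assay, > 100000 nM. Compound 2 `CCC(Oc1cc(C)nc2ccc(OC)cc12)C(=O)Nc1cc(C)cc(C)c1` gives a measured number in this assay, 79400 nM. Compound 3 `COc1ccc2nc(C)cc(OCC(=O)Nc3c(C)cccc3C)c2c1` likewise returns only a limit, > 100000 nM. Compound 3 therefore stands at the weak end of what this assay can report, alongside compound 1, whereas compound 2 is the only one of the three with a number rather than a limit; with two limits and one number, no order among the three can be drawn.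

Compound 4 `COc1ccc2nc(C)cc(OCC(=O)Nc3c(C)cncc3C)c2c1` has not yet been measured. Against compound 3 it differs in one place: 3,5-dimethylpyridin-4-yl in place of 2,6-dimethylphenyl on an amide-type nitrogen

The amide and the two methyl groups on the entering ring are kept. Given that compound 3 and compound 1 both sit at the limit of > 100000 nM in this assay, at which 2 of the 3 values shown sit, no shift beyond the scatter is expected for this step, and the estimated change is a step that the limit leaves unreadable from compound 3 to compound 4. Compound 4 is thus expected to come out near 120000 nM, within a range of 40000 nM to 400000 nM, and most probably again as a limit of this assay rather than a number.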

Compound 4, half-maximal inhibitory concentration: 12600 nM
The estimate for compound 4 lay 9.5-fold (0.98 log units) above the measured number, outside the stated range (below it).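

Replacing 2,6-dimethylphenyl with 3,5-dimethylpyridin-4-yl on an amide-type nitrogen is the only single-place change shown, and in this assay it gives an at least 7.9-fold lower number from compound 3 to compound 4 (0.89 log units; beyond the scatter). Compound 4 gives 12600 nM, a measured number rather than a limit, so this place on the amide responds to a change of one ring atom: the heavy-atom count stays the same, while the entering group carries 1 hydrogen-bond acceptor and the leaving group 0. The step can be stated only as a minimum, since compound 3 carries only a limit: the limit of > 100000 nM in this assay, at which 2 of the 4 values shown sit.

No measurement shown links the lower number to any property of the ring nitrogen, so the cause of the step remains unassigned. As far as these compounds go, it also remains open whether the step is specific to a pyridine nitrogen in the entering ring, or whether an amine or a carboxylic acid on that ring would lower the number in the same way.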